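The source may report more compounds than this note shows. Statements on the series, on what has been measured and on what is new or still open speak of the compounds shown alone.

Compound 1, `C=C1C[C@]2(C(=O)O)C[C@H]1CC[C@H]2[C@]1(C)CCC[C@@](C)(C(=O)OC)[C@H]1C(=O)O`: > 10000 nM
Compound 2, `C=CCCC#CC#CC#CCCCCCCCC(=O)O`: 10000 nM

In a functional assay on SF-268 cells (Homo sapiens) for cytotoxicity, read by sulforhodamine B assay, with a stated time of 3 days (a lower number here means a stronger inhibitor, a higher number a weaker inhibitor), compound 1 gives > 10000 nM, which is a limit of the assay and not a number. Compound 2 gives 10000 nM in this assay. For the measured compounds named here, of the two values shown, one sits at the limit of > 10000 nM in this assay, at which 1 of the 2 values shown sits, so compound 2 holds the only number. Compound 3, `CCCCC#CC#CC#CCCCCCCCC(=O)O`, differs from compound 2 by ethyl in place of vinyl on a saturated chain carbon, two bonds along the chain from a triple-bonded carbon. No measured step of this kind exists among the compounds shown, and the author expects from compound 2 to compound 3 a step of no change at the digits printed from compound 2 to compound 3 (within the scatter), none beyond the scatter. Compound 3 is therefore estimated at 10000 nM, between 4000 nM and 25000 nM.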

Compound 3, half-maximal inhibitory concentration: 10000 nM
Estimate against measurement, compound 3: no gap at the digits printed, and the stated range covers the measured number.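

In this assay, ethyl in place of vinyl on a saturated chain carbon, two bonds along the chain from a triple-bonded carbon, gives no change at the digits printed from compound 2 to compound 3 (within the scatter). For the compounds shown here, at this position, then, the double bond that leaves with the vinyl group makes no difference that this pair can detect in this assay. Compound 1 remains a limit of the assay and not a number: the limit of > 10000 nM in this assay, at which 1 of the 3 values shown sits.

The compounds shown leave open whether an amine or a phenyl group in place of the ethyl would give a value different from that of compound 3. They also leave open whether a longer chain at this position would do so.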